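Dropping a Methyl from the Ester Ring

The compounds below may be only part of what the source reports. "The series", "measured", "known", "first", "only" and "open" are said of these compounds alone.

Compound 1 `CC1=CC[C@H](C(C)C)c2cc(C)c(OC(=O)c3cccc(C)c3)cc21` carries a methyl group on the aromatic ring of its ester. In a functional assay on SK-LU-1 cells (Homo sapiens) for antiproliferative activity, read by sulforhodamine B assay, with a stated time of 48 h, tested at 50 uM (on this read-out higher numbers stand for more inhibition at the one concentration tested (going by the name of the read-out) and lower numbers for less inhibition), compound 1 is recorded as "not active" (no number reported), so no single number places it on the scale. A related compound, compound 2 `CC1=CC[C@H](C(C)C)c2cc(C)c(OC(=O)c3cccc(C(F)(F)F)c3)cc21`, bears a trifluoromethyl group on that ring instead, and in this assay compound 2 gives 18.3%, a small degree of inhibition. Compound 3 `CC1=CC[C@H](C(C)C)c2cc(C)c(OC(=O)c3ccccc3)cc21` has not yet been measured; it differs from compound 1 by a single change: hydrogen in place of methyl on an aromatic carbon. For the measured compounds named here, no measured pair shows what removing a methyl does in this assay, so the size of the step cannot be read from the data. Because compound 1 stands at "not active" (no number reported) and the closest measured relative compound 2 reaches only 18.3%, the change from compound 1 to compound 3 is expected to stay within the usual scatter, with compound 3 likely near the low end. Compound 3 is estimated to give about 8% in this assay, within a range from 0% to 25%.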

Compound 3, a percentage reported as inhibition, at one concentration (the size of the read-out at that concentration, not a potency): 37%
The estimate for compound 3 lay 29 percentage points below the measured number, outside the stated range (above it).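

With hydrogen on this aromatic carbon, inhibition is clearly measurable: in this assay compound 3 gives 37%, whereas compound 1, which carries a methyl there, is recorded as "not active" (no number reported), so the size of that step cannot be read. Replacing trifluoromethyl with hydrogen gives a number 18.7 percentage points higher from compound 2 to compound 3 (beyond the scatter), so among these three compounds, neither group at this place gives a reading above that of hydrogen. Nothing measured here explains why the reading moves with these changes.

On these data alone, it remains open how an amine, a carboxylic acid or a longer chain such as propyl would read on this same carbon. These single-concentration readings also leave open how potent compound 3 is, and whether the other two compounds would separate from it at another concentration.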